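The compounds below may be only part of what the source reports. "The series", "measured", "known", "first", "only" and "open" are said of these compounds alone.

Of the compounds shown here, two measured so far share one core. Compound 1 `COc1cc(Br)c(-c2nc3ccccc3[nH]2)cc1OC` gives 1510 nM in an assay for inhibition of Alpha amylase (Homo sapiens), with a stated time of 10 min; a higher number here means a weaker inhibitor, a lower number a stronger inhibitor. Compound 2 `COc1ccc(Br)cc1-c1nc2cc(F)ccc2[nH]1` gives 2600 nM in this assay; it carries the larger of the two numbers, yet the gap to compound 1 lies within the scatter of repeated measurements, so the two cannot be told apart. Compound 3 `COc1ccc(Br)cc1-c1nc2cc(Cl)ccc2[nH]1` is compound 2 with chloro in place of fluoro on an aromatic carbon. Among the compounds with values here, no measured pair shows this change, so its effect is not known. A small step, not beyond the scatter, is expected for a 1.3-fold lower number from compound 2 to compound 3 (0.11 log units; within the scatter). Compound 3 is accordingly expected to give about 2000 nM in this assay, within 800 nM to 5000 nM.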

Compound 3, half-maximal inhibitory concentration: 2620 nM
Compound 3: the middle estimate sits 1.3-fold (0.12 log units) below what was measured, within the range that was stated.
By their numbers in this assay, from the lowest: compounds 1, 2 and 3 (each within the scatter of the next).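

Chloro in place of fluoro on this aromatic carbon gives a 1.0-fold higher number from compound 2 to compound 3 (0.00 log units; within the scatter) and is the first change in one place that can be read here. In this assay, the two groups therefore cannot be told apart at this position of the shared core. No measurement at hand offers an explanation for this result. Still open, on these data alone, is whether a group of another kind at this position, such as an amine or a carboxylic acid, would shift the number beyond the scatter.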